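The compounds below may be only part of what the source reports. "The series", "measured", "known", "first", "only" and "open" are said of these compounds alone.

In a functional assay on A9L-m1 cells with A9 (Mus musculus) as the target (a lower number here means that less compound is needed, a higher number that more compound is needed for the effect), compound 1 `Clc1nccnc1C1CN2CCC1CC2` gives 1590000 nM, compound 2 `CCCCCOc1nccnc1C1CN2CCC1CC2` gives 9130000 nM, and compound 3 `CCCCCCOc1nccnc1C1CN2CCC1CC2` gives 520000 nM, the lowest of the three numbers. Compound 4 `CCCCCCSc1nccnc1C1CN2CCC1CC2` differs from compound 3 by hexylsulfanyl in place of hexyloxy on an aromatic carbon, with hexylsulfanyl in place of hexyloxy on an aromatic carbon. Three measured steps offer indirect guidance: a 5.7-fold higher number from compound 1 to compound 2 (0.76 log units; beyond the scatter) and a 3.1-fold lower number from compound 1 to compound 3 (0.49 log units; beyond the scatter) were modest, whereas an 18-fold lower number from compound 2 to compound 3 (1.24 log units; beyond the scatter) was large. For the measured compounds named here, none of them exchanges hexyloxy for hexylsulfanyl, so the data contain no direct precedent. The hexyl chain that accompanies the lowest number, in compound 3 at 520000 nM, stays in place, so no shift beyond the scatter is expected in this assay, and the expected step is a 1.2-fold lower number from compound 3 to compound 4 (0.06 log units; within the scatter). The estimated value for compound 4 is 450000 nM, within an expected range from 90000 nM to 2300000 nM.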

Compound 4, half-maximal effective concentration: 270000 nM
For compound 4 the middle estimate is 1.7-fold (0.22 log units) above the measured one; the range from low to high includes it.
By their numbers in this assay, from the lowest: compounds 4 and 3 (each within the scatter of the next); then compound 1; then compound 2.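

In this assay, hexylsulfanyl in place of hexyloxy on this aromatic carbon next to the ring nitrogen gives (a 1.9-fold lower number from compound 3 to compound 4 (0.28 log units; within the scatter)) , so the hexyl chain can be attached here through either sulfur or oxygen without a change beyond the scatter. Compound 4 also stands apart from the other two compounds, with (a 5.9-fold lower number from compound 1 to compound 4 (0.77 log units; beyond the scatter)) and (a 34-fold lower number from compound 2 to compound 4 (1.53 log units; beyond the scatter)) . Nothing given here accounts for these results. As far as these compounds go, it remains open whether a pentylsulfanyl or a longer chain such as octylsulfanyl would follow the oxygen series. From the compounds shown here alone, how an amine linking the hexyl chain at this carbon would compare also remains open.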